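Silicon in place of an amine on the antiproliferative core

This account rests on a few compounds, and the source may have more. Where it says the series, first, only, none or still open, it means among the compounds named here.

Compound 2 `CC(C)=CCC[C@]1(C)/C=C/[C@@H](OC(=O)C=C(C)C)[C@](C)(O)/C=C/C(=O)/C(CN(C)C)=C\C1` gives 590 nM in a functional assay on A549 cells (Homo sapiens) for antiproliferative activity, read by MTT assay, with a stated time of 48 h (on this read-out higher numbers stand for weaker inhibition and lower numbers for stronger inhibition), the lower of the two numbers recorded there; compound 1 `C=C1/C=C/C(=O)/C(CO)=C\C[C@](C)(CCC=C(C)C)/C=C/[C@H]1OC(=O)C=C(C)C` gives 3090 nM in this assay, a gap beyond the scatter. Among the measured compounds shown here, no single-point step between measured compounds is available, so the size of the next change cannot be anchored. Compound 3 `CC(C)=CCC[C@]1(C)/C=C/[C@@H](OC(=O)C=C(C)C)[C@](C)(O)/C=C/C(=O)/C(C[Si](C)(C)C(C)(C)C)=C\C1` carries a group of 7 heavy atoms (6 carbon, 1 silicon; no ring) in place of a group of 3 heavy atoms (2 carbon, 1 nitrogen; no ring), on a saturated chain carbon bound to a double-bonded ring carbon. The step of a 3.1-fold higher number from compound 2 to compound 3 (0.48 log units; beyond the scatter) is expected to be modest and toward weaker inhibition, though a result within the scatter would not surprise. Compound 3 is estimated at 1800 nM, with a range from 500 nM to 7000 nM.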

Compound 3, half-maximal inhibitory concentration: 4200 nM
Estimate against measurement, compound 3: 2.3-fold (0.37 log units) below; low and high end bracket the measured number.
By their numbers in this assay, from the lowest: compound 2; then compounds 1 and 3 (each within the scatter of the next).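

In this assay the silicon group of 7 heavy atoms in place of dimethylamino, on a saturated chain carbon bound to a double-bonded ring carbon, gives a 7.1-fold higher number from compound 2 to compound 3 (0.85 log units; beyond the scatter) and so provides the only single-place step shown. It shows that the number at this position responds to this exchange, which removes the group's 1 hydrogen-bond acceptor and leaves 0. No measurement given here accounts for the shift. From the compounds shown here alone, whether a morpholine or a trimethylsilyl group at this position would stay close to compound 2 remains open.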